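A few compounds are considered here, and "the series" means these few. Any claim that something is new, unique, unknown or untested is made for them only; others in the source may bear on it.

- compound 1 `Cc1ccccc1-n1cc(-c2ccc(/C=C3\C(=O)Nc4ccccc43)cc2)nn1`: 9770 nM
- compound 2 `O=C1Nc2ccccc2/C1=C/c1ccc(-c2cn(-c3ccccc3F)nn2)cc1`: 12500 nM

Both numbers come from a functional assay on MKN-45 cells (Homo sapiens) for inhibition, read by CCK-8 assay, with a stated time of 24 h; on this read-out higher numbers stand for weaker inhibition and lower numbers for stronger inhibition. For the measured compounds named here, with only two measurements, compound 2 cannot be separated from its one neighbour, and the measured step between them is a 1.3-fold higher number from compound 1 to compound 2 (0.11 log units; within the scatter). That step places fluoro in place of methyl on an aromatic carbon.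

The next compound to be tested is compound 3 `O=C1Nc2ccccc2/C1=C/c1ccc(-c2cn(-c3cccc(F)c3)nn2)cc1`, which has the same atoms as compound 2, joined differently: 3-fluorophenyl in place of 2-fluorophenyl on an aromatic nitrogen. In words, this is 3-fluorophenyl in place of 2-fluorophenyl on an aromatic nitrogen.

Going by the values given here, no measured pair shows what moving the fluoro does, so the data offer no direct guide. Among the compounds with values here, the only indirect evidence is the step of a 1.3-fold higher number from compound 1 to compound 2 (0.11 log units; within the scatter), which stayed within the scatter. A small result in one pair is weak evidence, yet nothing here points to a large change or favours a direction in this assay. The estimate therefore means a 1.1-fold lower number from compound 2 to compound 3 (0.06 log units; within the scatter), an expected step no larger than the scatter. For compound 3 the expected value is 11000 nM, with an estimated range from 4500 nM to 25000 nM.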

Compound 3, half-maximal inhibitory concentration: > 20000 nM
Compound 3 was reported as a limit; the forecaster's own chance of this, stated with the estimate: 7%; middle value at least 1.8-fold (0.25 log units) from the limit.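

In this assay compound 3 is reported only as a limit, not as a number: the limit of > 20000 nM in this assay, at which 1 of the 3 values shown sits. Moving the fluorine within the same atoms, from 2-fluorophenyl to 3-fluorophenyl on the aromatic nitrogen, gives an at least 1.6-fold higher number from compound 2 to compound 3 (0.20 log units; that floor lies within the scatter); the printed floor of this step does not yet separate the two compounds, though the true gap could be larger. For the compounds shown here, the comparison with the methyl compound is firmer, as 3-fluorophenyl in place of 2-methylphenyl gives an at least 2.0-fold higher number from compound 1 to compound 3 (0.31 log units; beyond the scatter), the first step in this small set to pass beyond the scatter, which shows that this aryl group on the aromatic nitrogen is not indifferent to every change.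

The limit leaves open how much weaker compound 3 really is, and therefore whether shifting the fluorine alone has a real effect in this assay. Also open is how the shared core would respond to an amine or a carboxylic acid on this phenyl ring, since the three compounds shown carry only a methyl or a fluorine there.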